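A few compounds are considered here, and "the series" means these few. Any claim that something is new, unique, unknown or untested is made for them only; others in the source may bear on it.

In an ADME assay on the whole organism for cytotoxicity, with Artemia salina as the target, with a stated time of 24 h (a lower number here means that less compound is needed, a higher number that more compound is needed for the effect), compound 3 `CCOc1cc(/C=C/C(=O)c2ccccc2NC(=O)NS(=O)(=O)c2ccc(C)cc2)ccc1O` gives 19.2 ug/mL. Among the three measured compounds its number is the second highest: compound 2 `COc1ccc(/C=C/C(=O)c2ccccc2NC(=O)NS(=O)(=O)c2ccc(C)cc2)c(OC)c1` gives 16 ug/mL and lies nearest, with the step of a 1.2-fold higher number from compound 2 to compound 3 (0.08 log units; within the scatter), while compound 1 `COc1ccc(/C=C/C(=O)c2ccccc2NC(=O)NS(=O)(=O)c2ccc(C)cc2)cc1` gives 28.1 ug/mL and lies furthest, with the step of a 1.5-fold lower number from compound 1 to compound 3 (0.17 log units; within the scatter). Both of these steps stay within the scatter, so the three measured compounds cannot be told apart on this assay.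

Compound 4 `Cc1ccc(S(=O)(=O)NC(=O)Nc2ccccc2C(=O)/C=C/c2ccc(Cl)cc2)cc1` differs from compound 3 only on the aryl ring at the end of the unsaturated chain: 4-chlorophenyl in place of 3-ethoxy-4-hydroxyphenyl on a double-bonded chain carbon bound to a double-bonded chain carbon. All three measured steps are changes on that same aryl ring. Besides the two steps already named, the step of a 1.8-fold lower number from compound 1 to compound 2 (0.24 log units; within the scatter) also stays within the scatter. The measured data therefore give no instance of a change at this position that moved this assay beyond its scatter, though none of those changes removed both oxygen-bearing groups at once or brought in a halogen.

On that basis the number for compound 4 is expected to stay close to that of compound 3, with a step of a 1.0-fold higher number from compound 3 to compound 4 (0.02 log units; within the scatter) that does not go beyond the scatter. Compound 4 is estimated at 20 ug/mL, with a range from 9 ug/mL to 45 ug/mL.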

Compound 4, concentration for half-maximal effect: 6.92 ug/mL
Compound 4: middle estimate off by 2.9-fold (0.46 log units), on the high side; the measured number lies below the stated range.
By their numbers in this assay, from the lowest: compound 4; then compounds 2, 3 and 1 (each within the scatter of the next).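

In this assay, going by these compounds alone, 4-chlorophenyl on a double-bonded chain carbon bound to a double-bonded chain carbon brings the first change at this position that goes beyond the scatter: the step is a 2.8-fold lower number from compound 3 to compound 4 (0.44 log units; beyond the scatter) and, measured against the other two, a 2.3-fold lower number from compound 2 to compound 4 (0.36 log units; beyond the scatter) and a 4.1-fold lower number from compound 1 to compound 4 (0.61 log units; beyond the scatter) at this same place. All three steps are modest and point the same way, so compound 4 stands apart from compounds 1, 2 and 3, which could not be told apart from one another, and this position proves able to move the number when chloro takes the place of the oxygen-bearing groups. Nothing in the data explains this shift, and with a single chloro compound the entry of chlorine cannot be separated from the loss of the oxygen-bearing groups.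

The compounds shown leave open whether plain phenyl, with no group at all in that place, would follow compound 4 or the oxygen-bearing compounds. They also leave open whether another halogen such as bromo or fluoro, or an amine or a carboxylic acid on the same ring, would move the number in the same direction.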